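This account rests on a few compounds, and the source may have more. Where it says the series, first, only, none or still open, it means among the compounds named here.

Measured set:
compound 1 `O=C(Nc1ccccc1)C(Cl)Cl` — 130000 nM
compound 2 `O=C(Nc1cccc(Cl)c1)C(Cl)Cl` — 14800 nM
compound 3 `N#Cc1cccc(NC(=O)C(Cl)Cl)c1` — 66500 nM

All three numbers come from a functional assay on A549 cells (Homo sapiens) for antiproliferative activity, read by MTT assay, with a stated time of 72 h; on this read-out lower numbers stand for stronger inhibition and higher numbers for weaker inhibition. Compound 1 stands at the highest number of the three: compound 3 sits within the scatter of it, compound 2 clearly beyond it. The two steps from compound 1 are an 8.8-fold lower number from compound 1 to compound 2 (0.94 log units; beyond the scatter) and a 2.0-fold lower number from compound 1 to compound 3 (0.29 log units; within the scatter). Between the two substituted analogues the difference is a 4.5-fold higher number from compound 2 to compound 3 (0.65 log units; beyond the scatter).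

Compound 4 `O=C(Nc1cccc(SC(F)(F)F)c1)C(Cl)Cl` differs from compound 1 in a single place: (trifluoromethyl)sulfanyl in place of hydrogen on an aromatic carbon. The entering group occupies the same aromatic carbon that carries chloro in compound 2 and cyano in compound 3. Both measured substitutions at this carbon move the number downward from compound 1, one modestly and beyond the scatter, the other within it. Within the data shown here, no measured compound carries the new group, so the expectation rests on these two steps alone. A lower number than compound 1 is expected, at about the size of the chloro step or slightly larger; the expected step is a 14-fold lower number from compound 1 to compound 4 (1.16 log units; beyond the scatter). Compound 4 is therefore estimated at 9000 nM, with a range from 2500 nM to 35000 nM.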

Compound 4, half-maximal inhibitory concentration: 14100 nM
Compound 4: the middle estimate sits 1.6-fold (0.19 log units) below what was measured; measured number inside the range.
By their numbers in this assay, from the lowest: compounds 4 and 2 (each within the scatter of the next); then compounds 3 and 1 (each within the scatter of the next).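

In this assay, a third group at this aromatic carbon gives a 9.2-fold lower number from compound 1 to compound 4 (0.96 log units; beyond the scatter), which, like an 8.8-fold lower number from compound 1 to compound 2 (0.94 log units; beyond the scatter), lies beyond the scatter. (Trifluoromethyl)sulfanyl and chloro cannot be told apart at this carbon, with a 1.0-fold lower number from compound 2 to compound 4 (0.02 log units; within the scatter), so two different groups now give values within the scatter of each other. Cyano stands apart from both, with a 4.7-fold lower number from compound 3 to compound 4 (0.67 log units; beyond the scatter) alongside a 4.5-fold higher number from compound 2 to compound 3 (0.65 log units; beyond the scatter), and compound 3 is the exception to a step beyond the scatter from compound 1 on substitution at this carbon, so the drop seen for compounds 2 and 4 does not hold for all three groups.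

No measurement shown bears on why chloro and (trifluoromethyl)sulfanyl give matching values while cyano does not. Also open, on these data alone, is whether a methoxy group, an amine or a carboxylic acid at this carbon would fall with compounds 2 and 4 or with compound 3, and whether changes elsewhere on the shared core would alter these steps.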